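The source may hold more compounds than are shown below. What is called first, only, known or untested is meant among the compounds shown, and "the series" means these compounds.

Measured so far in a functional assay on CHO-K1 cells for antagonist activity at C-X-C chemokine receptor type 3 (Homo sapiens), read by FLIPR, with a stated time of 10 min; on this read-out higher numbers stand for weaker inhibition and lower numbers for stronger inhibition:
- compound 1, `COCCOc1ncc(-c2nc(C(F)(F)F)sc2N2CCN(C(=O)Cn3cnc4cccnc43)[C@H](C)C2)cn1`, gives 4.7 nM
- compound 2, `CCOc1ncc(-c2nc(C(F)(F)F)sc2N2CCN(C(=O)Cn3ccc(C(F)(F)F)n3)[C@H](C)C2)cn1`, gives 3.8 nM
- compound 3, `Cc1nc(C)n(CC(=O)N2CCN(c3sc(C(F)(F)F)nc3-c3cnc(OC4CCC4)nc3)C[C@H]2C)n1`, gives 4 nM

All three values sit within the scatter of one another. Compound 3 holds the second highest of the three numbers; its nearest neighbour is compound 2, and the furthest is compound 1, with both gaps inside the usual scatter. On these numbers compound 3 is neither separated from compound 1 nor from compound 2, and no ordering among the three can be claimed.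

Compound 4, `Cc1nc(C)n(CC(=O)N2CCN(c3sc(C(F)(F)F)nc3-c3cnc(C(C)(C)C)nc3)C[C@H]2C)n1`, has not yet been measured. It differs from compound 3 in one place: tert-butyl in place of cyclobutyloxy on an aromatic carbon. Put plainly, tert-butyl in place of cyclobutyloxy on an aromatic carbon, with the 2-(cyclobutyloxy)pyrimidin-5-yl read as 2-(tert-butyl)pyrimidin-5-yl one bond further out. Among the measured compounds shown here, no pair of measured compounds shows this kind of exchange, so nothing sets its size. The three measured compounds all carry an alkoxy-type group at this carbon and all land close together, which gives no hint of sensitivity at that position but also no test of losing the oxygen. A small step toward higher numbers in this assay is expected, near the edge of the scatter, as a 2.0-fold higher number from compound 3 to compound 4 (0.30 log units; within the scatter). Compound 4 is estimated at 8 nM, with a range from 2.5 nM to 30 nM.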

Compound 4, half-maximal inhibitory concentration: 8.7 nM
For compound 4 the middle estimate is 1.1-fold (0.04 log units) below the measured one; low and high end bracket the measured number.
By their numbers in this assay, from the lowest: compounds 2, 3, 1 and 4 (each within the scatter of the next, the first and the last beyond it).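

In this assay, among the compounds shown here, tert-butyl in place of cyclobutyloxy on the aromatic carbon between two ring nitrogen atoms gives a 2.2-fold higher number from compound 3 to compound 4 (0.34 log units; beyond the scatter), the first step at this position that can be read, and a modest one. Compounds 1, 2 and 3 all kept an oxygen on this carbon, so they could not show whether the oxygen is needed; with no oxygen on this carbon, compound 4 still gives 8.7 nM, so the position accepts a purely carbon group at a modest cost. Nothing at hand explains the size of this step.

The exchange removes the oxygen and the four-membered ring together, so the step cannot be assigned to either one alone: a cyclobutyl group attached directly to the carbon, or an open-chain tert-butoxy group, would separate the two. Also open, going by these compounds, are how an amine such as dimethylamino or a carboxylic acid at this carbon would read out, and whether the same exchange gives a step of similar size with the different amide side groups of compound 1 and compound 2.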